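Fluorinated benzyl groups and the step to compound 4

The compounds below may be only part of what the source reports. "The series", "measured", "known", "first", "only" and "open" are said of these compounds alone.

compound 1 `O=C(Nc1ccc(-c2cscn2)cc1)C1CCCN(C(=O)c2ccc(F)c(F)c2)C1`: > 20000 nM (a limit of the assay)
compound 2 `O=C(Nc1ccc(-c2cscn2)cc1)C1CCCN(Cc2ccccc2F)C1`: 4000 nM
compound 3 `O=C(Nc1ccc(-c2cscn2)cc1)C1CCCN(Cc2cccc(F)c2F)C1`: 1480 nM

In a functional assay on A-375 cells (Homo sapiens) for antiproliferative activity (a higher number here means a weaker inhibitor, a lower number a stronger inhibitor), compound 3 gives 1480 nM as the lowest number, with compound 2 nearest at 4000 nM. The gap between these two lies beyond the scatter. Compound 1 at > 20000 nM is a limit of the assay and not a number.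

Compound 4 `O=C(Nc1ccc(-c2cscn2)cc1)C1CCCN(Cc2cccnc2)C1` carries pyridin-3-yl in place of 2,3-difluorophenyl on a saturated chain carbon bound to an amine nitrogen in a ring. The closest guide is the modest fluoro-for-hydrogen step (a 2.7-fold lower number from compound 2 to compound 3 (0.43 log units; beyond the scatter)). The larger steps (an at least 5.0-fold lower number from compound 1 to compound 2 (0.69 log units; beyond the scatter)) and (an at least 13-fold lower number from compound 1 to compound 3 (1.13 log units; beyond the scatter)) replace the carbonyl-linked group, a change absent here, and both rest on a limit, so they bear only loosely. Going by the values given here, no measured compound has a hetero atom in this ring, which leaves the size uncertain. A modest move to a higher number is expected (a 3.0-fold higher number from compound 3 to compound 4 (0.48 log units; beyond the scatter)). Compound 4 is estimated at 4500 nM (expected range 1800 nM to 14000 nM).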

Compound 4, half-maximal inhibitory concentration: > 20000 nM
Compound 4: no number, only a limit (the forecaster's own chance of this, stated with the estimate: 15%); at least 4.4-fold (0.64 log units) between middle value and limit.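

In this assay, pyridin-3-yl in place of 2,3-difluorophenyl on a saturated chain carbon bound to an amine nitrogen in a ring gives an at least 13-fold higher number from compound 3 to compound 4 (1.13 log units; beyond the scatter), and in place of 2-fluorophenyl it gives an at least 5.0-fold higher number from compound 2 to compound 4 (0.69 log units; beyond the scatter). Compound 4 keeps the saturated chain carbon of compound 2 and compound 3, so among these compounds that link alone does not secure a measurable number, and the ring on it matters as well. Both step sizes are minimums, and the step from compound 1 cannot be read, because compound 4 also sits at a limit of the assay: the limit of > 20000 nM in this assay, at which 2 of the 4 values shown sit.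

The compounds shown do not separate the gain of the ring nitrogen from the loss of fluoro; an unsubstituted benzyl or a fluoro-bearing pyridin-3-yl would bear on that. On these data alone, whether pyridin-2-yl or pyridin-4-yl behaves in the same way also stays open.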